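The source may report more compounds than this note shows. Statements on the series, on what has been measured and on what is new or still open speak of the compounds shown alone.

In a functional assay on A549 cells (Homo sapiens) for cytotoxicity, read by MTT assay, with a stated time of 68 h (a higher number here means a weaker inhibitor, a lower number a stronger inhibitor), three compounds with a shared core have been measured so far. Compound 1 `Nc1cccc(-c2cccc(NC(=O)C(Cl)Cl)c2)c1`, which carries an amino group, gives 50000 nM. Compound 2 `O=C(Nc1cccc(-c2cccc(F)c2)c1)C(Cl)Cl`, with fluoro in place of that amino group, gives 9530 nM, the lower of the two actual numbers. For compound 3 `O=C(Nc1cccc(-c2ccsc2)c1)C(Cl)Cl` the assay reports a limit, > 50000 nM, and not a number.

The next compound is compound 4 `COc1cccc(-c2cccc(NC(=O)C(Cl)Cl)c2)c1`. Its difference from compound 2 is methoxy in place of fluoro on an aromatic carbon, meta to a large group. Among the measured compounds shown here, only one measured step bears on this change, a 5.2-fold lower number from compound 1 to compound 2 (0.72 log units; beyond the scatter), which is modest but beyond the scatter. For the measured compounds named here, it shows that swapping the group at this place can move the number, but no measured compound shows what methoxy itself does. A modest step is therefore the best guide to its size. The direction is less certain, although a higher number seems more likely, since compound 2 at 9530 nM already has the lowest number seen. The expected change is a 1.9-fold higher number from compound 2 to compound 4 (0.28 log units; within the scatter), a modest weakening with real uncertainty. Compound 4 is estimated at 18000 nM, with an expected range from 6000 nM to 50000 nM.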

Compound 4, half-maximal inhibitory concentration: 4310 nM
Estimate against measurement, compound 4: 4.2-fold (0.62 log units) above, and the stated range ends above it.
By their numbers in this assay, from the lowest: compound 4; then compound 2; then compound 1.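

In this assay, among the compounds shown here, the earlier compounds offered only one swap at this place, on an aromatic carbon meta to a large group, and it left fluoro with the lowest number; methoxy now goes lower still, with a 2.2-fold lower number from compound 2 to compound 4 (0.34 log units; beyond the scatter). Set against the amino group, the same position gives a 12-fold lower number from compound 1 to compound 4 (1.06 log units; beyond the scatter), so this single place on the shared core can carry a large change in the number, and the three groups now stand in the order methoxy, fluoro, amino, from lowest to highest. Nothing measured here says why methoxy gives a lower number than fluoro or amino.

Compound 3 gives > 50000 nM, which is a limit and not a number, so its different ring cannot be placed in this order, and the steps to it cannot be read. From the compounds shown here alone, whether the trend continues with a larger ether such as ethoxy, or changes with a hydroxyl group, a chlorine atom or a carboxylic acid at the same position, remains open.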